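Heteroaryl variation at the thiazole-adjacent position of the series

A few compounds are considered here, and "the series" means these few. Any claim that something is new, unique, unknown or untested is made for them only; others in the source may bear on it.

Measured compounds:
compound 1 `O=C(O)Cc1sc(C(c2ccc(F)cc2)c2ccc(F)cc2)nc1-c1ccccc1`, 16 nM
compound 2 `O=C(O)Cc1sc(C(c2ccc(F)cc2)c2ccc(F)cc2)nc1-c1cccc(F)c1`, 1.4 nM
compound 3 `O=C(O)Cc1sc(C(c2ccc(F)cc2)c2ccc(F)cc2)nc1-c1cn[nH]c1`, 16 nM

All three share one core and differ only in the aromatic group on the ring carbon next to the ring nitrogen. In an in vitro assay on HEK385-7 cells for displacement of a labelled ligand from prostaglandin D2 receptor 2 (Homo sapiens) (on this read-out higher numbers stand for weaker inhibition and lower numbers for stronger inhibition), compound 1 gives 16 nM and compound 2 gives 1.4 nM, a step of an 11-fold lower number from compound 1 to compound 2 (1.06 log units; beyond the scatter). Compound 3, with 1H-pyrazol-4-yl at that position, gives 16 nM; the step of no change at the digits printed from compound 1 to compound 3 (within the scatter), so compound 3 and compound 1 stand level and together at the high end of the three numbers, while an 11-fold higher number from compound 2 to compound 3 (1.06 log units; beyond the scatter).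

Compound 4 `O=C(O)Cc1sc(C(c2ccc(F)cc2)c2ccc(F)cc2)nc1-c1ccnc(O)c1` carries 2-hydroxypyridin-4-yl in place of 1H-pyrazol-4-yl on an aromatic carbon. Going by the values given here, no measured step covers a hydroxyl-bearing six-membered heteroaryl here. Among the compounds with values here, the only steps that bear on this change are the swap of phenyl for pyrazolyl, which left the number unchanged, and the large gain seen only with 3-fluorophenyl, which compound 4 does not carry. Within the data shown here, a 2-hydroxypyridin-4-yl returns to a six-membered ring, as in compound 1, but adds polar atoms that have no precedent. The expectation for compound 4 is therefore a step of about a 1.3-fold higher number from compound 3 to compound 4 (0.10 log units; within the scatter), within or near the scatter, with no firm direction. Compound 4 is estimated at 20 nM, with a range of 5 nM to 80 nM.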

Compound 4, half-maximal inhibitory concentration: 68 nM
Compound 4: middle estimate off by 3.4-fold (0.53 log units), on the low side; low and high end bracket the measured number.
By their numbers in this assay, from the lowest: compound 2; then compounds 1 and 3 (each within the scatter of the next); then compound 4.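

In this assay this position is not indifferent to which heteroaryl group it carries: the pyrazolyl swap left the number unchanged, whereas 2-hydroxypyridin-4-yl gives a 4.3-fold higher number from compound 3 to compound 4 (0.63 log units; beyond the scatter) and, measured against the phenyl group, a 4.3-fold higher number from compound 1 to compound 4 (0.63 log units; beyond the scatter). Going by these compounds alone, compound 4 now stands highest of the four, and the distance from the 3-fluorophenyl group reaches a 49-fold higher number from compound 2 to compound 4 (1.69 log units; beyond the scatter), so the span of numbers at this position is wider than the earlier compounds showed. Nothing at hand accounts for the rise in the number with 2-hydroxypyridin-4-yl.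

As far as these compounds go, compound 4 differs from compound 1 in two ways at once, a ring nitrogen and a hydroxyl, so it remains open which of them goes with the step; pyridin-4-yl and 2-methoxypyridin-4-yl would help to separate the two. Also open, from the compounds shown here alone, is whether the lower number of compound 2 is particular to fluoro or also comes with a chloro or a methyl group on that phenyl ring.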